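Swapping the aryl amide in a chlorinated cyclic hydrazone series

The source may hold more compounds than are shown below. What is called first, only, known or untested is meant among the compounds shown, and "the series" means these compounds.

Measured compounds:
compound 1, `Cc1ccc(/C=N\NC(=O)C2=C(Cl)c3ccccc3CCC2)cc1`, 2300 nM
compound 2, `COc1ccc(/C=N\NC(=O)C2=C(Cl)c3ccccc3CCC2)c(OC)c1`, 38500 nM
compound 3, `Cc1ccc(C(=O)N/N=C/C2=C(Cl)c3cc(C)c(C)cc3CCC2)cc1`, > 100000 nM

Of the compounds shown here, three have been tested in a functional assay on HeLa cells (Homo sapiens) for inhibition, read by sulforhodamine B assay, with a stated time of 48 h; a lower number here means a stronger inhibitor of growth, a higher number a weaker inhibitor of growth. Compound 1 gives 2300 nM and compound 2 gives 38500 nM. For compound 3 the value > 100000 nM is a limit of the assay and not a number. Compound 3 therefore sits at the limit of > 100000 nM in this assay, at which 1 of the 3 values shown sits, the weakest position that the data can show.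

Compound 4, `Cc1cc2c(cc1C)C(Cl)=C(/C=N/NC(=O)c1cccc(Cl)c1)CCC2`, has not yet been tested in this assay. It differs from compound 3 in one place: 3-chlorophenyl in place of 4-methylphenyl on a carbonyl carbon. Among the compounds with values here, compounds 1 and 2 do not share this arrangement of the hydrazone, so they give no step that bears directly on the change. With compound 3 at a limit, no direction can be read from the numbers, and the step of an at least 1.2-fold lower number from compound 3 to compound 4 (0.09 log units; that floor lies within the scatter) is expected to be small or to leave compound 4 at the limit as well. Compound 4 is therefore estimated at 80000 nM, with a range from 20000 nM to 250000 nM.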

Compound 4, concentration for 50% growth inhibition: 770 nM
Beside the measured number, compound 4's estimate is 100-fold (2.02 log units) above it; the measured number lies below the stated range.
By their numbers in this assay, from the lowest: compound 4; then compound 1; then compound 2. At a limit, above all of these: compound 3.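

With the rest of the structure held fixed, 3-chlorophenyl in place of 4-methylphenyl on a carbonyl carbon gives an at least 120-fold lower number from compound 3 to compound 4 (2.11 log units; beyond the scatter) in this assay. Within the data shown here, compounds 1 and 2 offered no one-place step, so this is the first evidence that this position alone can move the number beyond the scatter. Compound 3 stands at a limit of the assay and not at a number, so the step gives only a floor for the size of the change: the limit of > 100000 nM in this assay, at which 1 of the 4 values shown sits.

The compounds shown leave open whether the chlorine itself or simply the loss of the methyl accounts for the step. They also leave open how a phenyl carrying an amine or a carboxylic acid would read in this place in this assay.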